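Coumarin-linked pyrazole imines: phenoxy change at the assay limit

The source may report more compounds than this note shows. Statements on the series, on what has been measured and on what is new or still open speak of the compounds shown alone.

Working notes on the series. Compound 1, `Cc1nn(C)c(Oc2ccc(Br)cc2)c1/C=N\CCCCCOc1cc2oc(=O)cc(C)c2cc1Cl`, has in a functional assay on SMMC-7721 cells (Homo sapiens) for antiproliferative activity, read by MTT assay, with a stated time of 72 h (a lower number here means a stronger inhibitor, a higher number a weaker inhibitor), only the entry "not determined" (no result reported). Within the data shown here, compound 2, `Cc1nn(C)c(Oc2ccccc2F)c1/C=N\CCCCCCOc1cc2oc(=O)cc(C)c2cc1Cl`, is the single compound with a reported result. In this assay compound 2 gives > 25000 nM, which is a limit of the assay and not a number. Compound 2 thus stands at the limit of > 25000 nM in this assay, at which 1 of the 2 values shown sits, and its place among the numbers shown is known only as that limit. Among the measured compounds shown here, no step between two measured compounds is available. Compound 3, `Cc1nn(C)c(Oc2ccc(Br)cc2)c1/C=N\CCCCCCOc1cc2oc(=O)cc(C)c2cc1Cl`, has not been measured. It differs from compound 2 in one place: 4-bromophenyl in place of 2-fluorophenyl on an oxygen on an aromatic ring. With compound 2 already at the limit, no step beyond the scatter in this assay is expected from this change, in either direction. For compound 3 the estimated value in this assay is 30000 nM, within a range from 10000 nM to 100000 nM. The expected step that the limit leaves unreadable from compound 2 to compound 3 is essentially none, most likely again a limit.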

Compound 3, half-maximal inhibitory concentration: 3090 nM
Estimate against measurement, compound 3: 9.7-fold (0.99 log units) above; the whole stated range lies above it.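

The position on the phenoxy oxygen is not silent in this assay: 4-bromophenyl in place of 2-fluorophenyl on an oxygen on an aromatic ring gives an at least 8.0-fold lower number from compound 2 to compound 3 (0.90 log units; beyond the scatter) with the rest of the structure unchanged. Compound 2 alone could not show that this place in the series can move the read-out off the limit, and compound 3 now supplies the first actual number. The size of the step is bounded on one side only, since compound 2 sits at a limit of the assay: the limit of > 25000 nM in this assay, at which 1 of the 3 values shown sits.

The change alters both the halogen and its place on the ring, and the compounds shown do not separate the two. As far as these compounds go, a plain phenyl, or a phenyl bearing an amine or a carboxylic acid, stands among none of them, and what such groups would do at this position remains open.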